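Substituent changes on the thiophene-bearing core and reductase inhibition

A few compounds are considered here, and "the series" means these few. Any claim that something is new, unique, unknown or untested is made for them only; others in the source may bear on it.

Measured so far:
compound 1 `CCCCCCCCc1c(-c2ccccc2)sc(C(C)C)c1/C=C/[C@@H](O)C[C@@H](O)CC(=O)O`; an assay on microsomes for inhibition of 3-hydroxy-3-methylglutaryl-coenzyme A reductase (Rattus norvegicus); on this read-out higher numbers stand for weaker inhibition and lower numbers for stronger inhibition: > 10000 nM
compound 2 `CC(C)=Cc1c(-c2ccccc2)sc(C(C)C)c1/C=C/[C@@H](O)C[C@@H](O)CC(=O)O`; this assay: 1000 nM

Compound 1 reaches only the limit of this assay, a limit rather than a number (the limit of > 10000 nM in this assay, at which 1 of the 2 values shown sits). Compound 2 therefore holds the only number shown; the other value is a limit. The step of an at least 10-fold lower number from compound 1 to compound 2 (1.00 log units; beyond the scatter) is at least modest and beyond the scatter.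

Compound 3 `CC(C)c1sc(-c2ccccc2)c(C2CCCC2)c1/C=C/[C@@H](O)C[C@@H](O)CC(=O)O` is not yet measured. The change is cyclopentyl in place of 2-methylprop-1-en-1-yl on an aromatic carbon. Among the compounds with values here, the only measured step concerns the same position, where a long chain gave way to a short branched group, and the group now entering is of comparable size to the one leaving. A step within the scatter, or at most a small one, is expected in this assay, in either direction.

Compound 3 is estimated at 700 nM, with a range from 200 nM to 3000 nM. The expected step is a 1.4-fold lower number from compound 2 to compound 3 (0.15 log units; within the scatter).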

Compound 3, half-maximal inhibitory concentration: 417 nM
Estimate against measurement, compound 3: 1.7-fold (0.22 log units) above; the measured number falls inside the stated range.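

At the ring atom two ring bonds from the ring sulfur, cyclopentyl in place of 2-methylprop-1-en-1-yl gives a 2.4-fold lower number from compound 2 to compound 3 (0.38 log units; beyond the scatter) in this assay, so the double bond outside aromatic rings in the leaving group is not required for a measured number at this position, and a five-membered non-aromatic ring of carbon only serves at least as well. Set against the octyl group, the same cyclopentyl group gives an at least 23-fold lower number from compound 1 to compound 3 (1.37 log units; beyond the scatter). The value of compound 1 is a limit and not a number: the limit of > 10000 nM in this assay, at which 1 of the 3 values shown sits.

The compounds shown leave open whether a cyclohexyl ring, a short unbranched ethyl chain or a ring carrying an amine would hold or lower the number at this position. They also leave open how far the isopropyl and phenyl groups can be exchanged, as all three compounds carry both unchanged.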